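One halogen swap, seen twice, on two different cores

The compounds below may be only part of what the source reports. "The series", "measured", "known", "first", "only" and "open" are said of these compounds alone.

Two pairs of compounds share a single structural change. Compound 1 `CC(C)=CCC/C(C)=C/CC/C(C)=C/CC[C@@H]1[C@@]2(C)CC/C(=N\OCc3cn(-c4ccc(F)cc4)nn3)C(C)(C)[C@@H]2CC[C@@]1(C)O` and compound 2 `CC(C)=CCC/C(C)=C/CC/C(C)=C/CC[C@@H]1[C@@]2(C)CC/C(=N\OCc3cn(-c4ccc(Cl)cc4)nn3)C(C)(C)[C@@H]2CC[C@@]1(C)O` differ only in that (chloro in place of fluoro on an aromatic carbon). In a functional assay on A549 cells (Homo sapiens) for cytotoxicity, read by MTT assay, with a stated time of 48 h (a lower number here means a stronger inhibitor, a higher number a weaker inhibitor), compound 1 gives 18000 nM, and compound 2 gives 12300 nM, which amounts to a 1.5-fold lower number from compound 1 to compound 2 (0.17 log units; within the scatter). Compound 3 `CC(C)=CCC/C(C)=C/CC/C(C)=C/CC[C@@H]1[C@@]2(C)C/C(=C\c3ccc(OCc4cn(-c5ccc(F)cc5)nn4)cc3)C(=O)C(C)(C)[C@@H]2CC[C@@]1(C)O` carries the same fluoro group on a different core; the difference between the two cores is not broken down here. In this assay compound 3 gives 55200 nM, the highest of the three numbers measured. Compound 4 `CC(C)=CCC/C(C)=C/CC/C(C)=C/CC[C@@H]1[C@@]2(C)C/C(=C\c3ccc(OCc4cn(-c5ccc(Cl)cc5)nn4)cc3)C(=O)C(C)(C)[C@@H]2CC[C@@]1(C)O` has not yet been measured and differs from compound 3 in that (chloro in place of fluoro on an aromatic carbon), the same change at a place described in the same words as before. Because the earlier step was a 1.5-fold lower number from compound 1 to compound 2 (0.17 log units; within the scatter), a similarly small step is expected here, a 1.4-fold lower number from compound 3 to compound 4 (0.14 log units; within the scatter). For compound 4 the estimated value in this assay is 40000 nM, with a likely range from 15000 nM to 110000 nM, which rests on compound 3 giving 55200 nM.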

Compound 4, half-maximal inhibitory concentration: 83200 nM
Beside the measured number, compound 4's estimate is 2.1-fold (0.32 log units) below it; measured number inside the range.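

On the second core, putting chloro in place of fluoro gives a 1.5-fold higher number from compound 3 to compound 4 (0.18 log units; within the scatter) in this assay, a step too small to separate the two compounds. Set beside the step on the first core, it lies on the other side of zero, but the gap between the two is no larger than repeated measurements could produce: the same change on two cores in this assay, a 1.5-fold lower number (0.17 log units; within the scatter) from compound 1 to compound 2 and a 1.5-fold higher number (0.18 log units; within the scatter) from compound 3 to compound 4, 2.2-fold (0.34 log units) apart, within the scatter of two such steps. This shows that going from 4-fluorophenyl to 4-chlorophenyl makes no readable difference on either core, which fits the change carrying over as a small step; it does not show a real effect in either direction, and two pairs of compounds give no general rule.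

The compounds shown carry only fluoro or chloro at this place on the aromatic ring, leaving open what a larger change there, such as a methoxy group, a nitrile or an amine, would do on either core. Also open is how this swap behaves outside this assay, the only assay shown.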